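The source may report more compounds than this note shows. Statements on the series, on what has been measured and on what is new or still open speak of the compounds shown alone.

Three compounds sharing one core have been examined in an ADME assay on L02 cells (Homo sapiens) for cytotoxicity, read by MTT assay, with a stated time of 48 h; on this read-out higher numbers stand for weaker inhibition and lower numbers for stronger inhibition. Compound 1, `O=C1CSC(=O)N1C[C@H]1CN(c2ccc(-n3cc(-c4ccccn4)cn3)c(F)c2)C(=O)O1`, carries a 2,4-dioxo-1,3-thiazolidin-3-yl group on a saturated chain carbon bound to a saturated ring carbon. In this assay compound 1 reaches only the limit of > 400 ug/mL. Compound 2, `COC[C@H]1CN(c2ccc(-n3cc(-c4ccccn4)cn3)c(F)c2)C(=O)O1`, has methoxy in place of that group, and in this assay compound 2 likewise stops at the limit of > 400 ug/mL. Compound 3, `O=CNC[C@H]1CN(c2ccc(-n3cc(-c4ccccn4)cn3)c(F)c2)C(=O)O1`, has formylamino at the same place, and in this assay compound 3 also reaches only the limit of > 400 ug/mL. Consequently a step that the two limits leave unreadable from compound 1 to compound 2, a step that the two limits leave unreadable from compound 1 to compound 3 and a step that the two limits leave unreadable from compound 2 to compound 3 cannot be sized; what is known is the limit of > 400 ug/mL in this assay, at which 3 of the 3 values shown sit. Compound 4 is `CN(C)S(=O)(=O)NC[C@H]1CN(c2ccc(-n3cc(-c4ccccn4)cn3)c(F)c2)C(=O)O1`. It differs from compound 1 by (dimethylsulfamoyl)amino in place of 2,4-dioxo-1,3-thiazolidin-3-yl on a saturated chain carbon bound to a saturated ring carbon. The three changes made so far at this position bear on the present step only in the sense that none of them brought the read-out within the measurable window. Compound 4 is therefore expected to behave in this assay in the same way, with an expected step that the limit leaves unreadable from compound 1 to compound 4 that is a guess rather than a reading. The estimate for compound 4 is 450 ug/mL, with a range from 300 ug/mL to 800 ug/mL, and most likely the assay again reports only a limit.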

Compound 4, half-maximal inhibitory concentration: 158 ug/mL
For compound 4 the middle estimate is 2.8-fold (0.45 log units) above the measured one; the measured number lies below the stated range.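

In this assay, this position on a saturated chain carbon bound to a saturated ring carbon proves able to shift the read-out towards stronger inhibition: (dimethylsulfamoyl)amino gives an at least 2.5-fold lower number from compound 1 to compound 4 (0.40 log units; beyond the scatter), and in place of methoxy it gives an at least 2.5-fold lower number from compound 2 to compound 4 (0.40 log units; beyond the scatter). At the amine nitrogen, dimethylsulfamoyl in place of formyl gives an at least 2.5-fold lower number from compound 3 to compound 4 (0.40 log units; beyond the scatter), so what is attached to that nitrogen, and not the nitrogen alone, separates a measurable number from a limit in this pair. The true size of each of these steps remains unknown and the steps among the other compounds cannot be read, as the comparison rests on the limit: the limit of > 400 ug/mL in this assay, at which 3 of the 4 values shown sit.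

The compounds shown do not tell whether the change in read-out follows the sulfonyl unit as such or the two methyl groups on its far nitrogen, a question that a methanesulfonylamino or a diethylsulfamoylamino group at the same place would address. They also leave open how a free amine or a carboxylic acid at this position would read in this assay.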